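This account rests on a few compounds, and the source may have more. Where it says the series, first, only, none or still open, it means among the compounds named here.

Notes on the series in an ADME assay on BJ cells (Homo sapiens) for cytotoxicity, with a stated time of 72 h; on this read-out lower numbers stand for an effect already at smaller amounts and higher numbers for an effect only at larger amounts of compound. Compound 1 `C=C[C@@](C)(/C=C/c1ccc(O)cc1)CC/C=C/C(=O)OCC` is reported only as a limit, > 36600 nM. Within the data shown here, compound 2 `COc1ccc(/C=C/[C@@](C)(/C=C/c2ccc(O)c(C=O)c2)CCC=C(C)C)cc1` gives 9800 nM, the only true number so far. Compound 3 `COc1ccc(/C=C/[C@@](C)(/C=C/c2ccc(O)c(/C=C/C(=O)OCc3ccccc3)c2)CCC=C(C)C)cc1` keeps the core of compound 2 and changes in one place: 2-(benzyloxycarbonyl)ethenyl in place of formyl on an aromatic carbon. The 2-(benzyloxycarbonyl)ethenyl takes the place of formyl on an aromatic carbon, ortho to a hydroxy group. Among the measured compounds shown here, no measured step between compounds differing in one place is available, so the expectation is loose. In this assay, a modest move towards lower numbers is expected, not far beyond the scatter. The estimated change is a 1.6-fold lower number from compound 2 to compound 3 (0.21 log units; within the scatter). For compound 3 the expected value is 6000 nM, with an estimated range from 2000 nM to 20000 nM.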

Compound 3, half-maximal effective concentration: > 36600 nM
Compound 3: a limit, no number; the forecaster's own chance of this, stated with the estimate: 15%; middle value at least 6.1-fold (0.78 log units) away from the limit.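

In this assay, the aromatic carbon ortho to a hydroxy group is not indifferent to what it carries: 2-(benzyloxycarbonyl)ethenyl in place of formyl gives an at least 3.7-fold higher number from compound 2 to compound 3 (0.57 log units; beyond the scatter). Compound 3 is reported only as a limit, > 36600 nM. This single step therefore gives a direction and a minimum size for the change at this position, not its true size: the limit of > 36600 nM in this assay, at which 2 of the 3 values shown sit.

The compounds shown leave open whether the step follows from the loss of formyl or from the entry of 2-(benzyloxycarbonyl)ethenyl as a whole, including its six-membered aromatic ring. A carboxylic acid or an amine on this same aromatic carbon, with the rest of compound 2 unchanged, would help separate these two readings.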